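Moving the Ketone to the Other Oxadiazole Carbon

The compounds below may be only part of what the source reports. "The series", "measured", "known", "first", "only" and "open" are said of these compounds alone.

Compound 1 `O=C(CCCCCCc1ccccc1)c1ncno1` carries a 1,2,4-oxadiazol-5-yl group on a ketone that ends in a phenyl-terminated chain. In an assay on isolated protein for inhibition of neutral cholesterol ester hydrolase 1 (Homo sapiens) (on this read-out lower numbers stand for stronger inhibition and higher numbers for weaker inhibition), compound 1 gives 25000 nM. Compound 2 `O=C(CCCCCCc1ccccc1)c1nc(-c2ccccn2)no1` gives 30000 nM in this assay, and compound 3 `COC(=O)c1cccc(-c2noc(C(=O)CCCCCCc3ccccc3)n2)n1` gives 40000 nM. Compound 1 therefore holds the lowest of the three numbers, but the separations are small: a 1.2-fold higher number from compound 1 to compound 2 (0.08 log units; within the scatter), and a 1.3-fold higher number from compound 2 to compound 3 (0.12 log units; within the scatter). Both of these steps place a group on an aromatic carbon of the shared core, and neither moves the number beyond the scatter.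

Compound 4 `O=C(CCCCCCc1ccccc1)c1ncon1` is the unmeasured partner of compound 1; the two differ by 1,2,4-oxadiazol-3-yl in place of 1,2,4-oxadiazol-5-yl on a carbonyl carbon. Going by the values given here, no measured step bears directly on this change, since the two measured steps add groups to the ring rather than alter how the ring joins the carbonyl carbon. With the three measured numbers lying so close together, the step of no change at the digits printed from compound 1 to compound 4 (within the scatter) is expected to stay within the scatter in this assay. Compound 4 is accordingly estimated at 25000 nM, with a range from 8000 nM to 80000 nM.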

Compound 4, half-maximal inhibitory concentration: > 100000 nM
Compound 4 gave a limit, no number; the forecaster's own chance of this, stated with the estimate: 20%; middle value at least 4.0-fold (0.60 log units) away from the limit.
By their numbers in this assay, from the lowest: compounds 1, 2 and 3 (each within the scatter of the next). At a limit, above all of these: compound 4.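

The earlier steps shown here placed groups on an aromatic carbon of the ring and stayed within the scatter, but how the ring joins the carbonyl carbon proved to matter: 1,2,4-oxadiazol-3-yl in place of 1,2,4-oxadiazol-5-yl gives an at least 4.0-fold higher number from compound 1 to compound 4 (0.60 log units; beyond the scatter). This change keeps the same atoms and the same counts of donors and acceptors, so the shift comes with a difference in how those atoms are joined, not in what they are. The value of compound 4 is a limit and not a number: the limit of > 100000 nM in this assay, at which 1 of the 4 values shown sits.

The compounds shown leave open whether the 1,2,4-oxadiazol-3-yl ketone would respond to a pyridin-2-yl group as the core of compound 1 does. They also leave open what a carboxylic acid in place of the methoxycarbonyl group, or a longer chain, would do to the number.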